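This account rests on a few compounds, and the source may have more. Where it says the series, first, only, none or still open, it means among the compounds named here.

Measured compounds in an assay on isolated protein for inhibition of sphingosine kinase 1 (Homo sapiens), read by mobility shift assay; on this read-out lower numbers stand for stronger inhibition and higher numbers for weaker inhibition:
- compound 1 `CCCCCCCCc1ccc(NC(=O)[C@H](N)CO)cc1`: 5000 nM
- compound 2 `CCCCCCCCc1ccc(NC(=O)C(C)(N)CO)cc1`: > 10000 nM, a limit of the assay
- compound 3 `CCCCCCCCc1ccc(NC(=O)[C@H](N)[C@H](C)O)cc1`: 2100 nM

Compound 3 holds the lowest of the two numbers in this assay; its nearest neighbour is compound 1, with a 2.4-fold lower number from compound 1 to compound 3 (0.38 log units; beyond the scatter). Compound 2 sits at the limit (the limit of > 10000 nM in this assay, at which 1 of the 3 values shown sits), so its step to compound 3 is only a floor, an at least 4.7-fold lower number from compound 2 to compound 3 (0.67 log units; beyond the scatter), as is an at least 2.0-fold higher number from compound 1 to compound 2 (0.30 log units; that floor lies within the scatter).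

Compound 4 `CCCCCCCCc1ccc(NC[C@H]2NCC[C@@H]2O)cc1` differs from compound 3 in one place: (3-hydroxypyrrolidin-2-yl)methyl in place of (1-amino-2-hydroxypropyl)carbonyl on a nitrogen on an aromatic ring. Neither measured step touches this change. Both alter only the group on the carbonyl carbon or the substituent on the saturated chain carbon bound to oxygen, while the carbonyl itself stays in place; here the (1-amino-2-hydroxypropyl)carbonyl group is exchanged for a (3-hydroxypyrrolidin-2-yl)methyl group, and the amide link disappears. The measured steps were at most modest, so no step beyond the scatter is expected in either direction.

Compound 4 is expected to give 3500 nM in this assay, with a range from 1000 nM to 12000 nM. For compound 4 this expectation means a 1.7-fold higher number from compound 3 to compound 4 (0.22 log units; within the scatter), within the scatter.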

Compound 4, half-maximal inhibitory concentration: 740 nM
For compound 4 the middle estimate is 4.7-fold (0.67 log units) above the measured one, outside the stated range (below it).
By their numbers in this assay, from the lowest: compound 4; then compound 3; then compound 1. At a limit, above all of these: compound 2.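

In this assay, within the data shown here, the group on the nitrogen on an aromatic ring tolerates loss of the carbonyl: (3-hydroxypyrrolidin-2-yl)methyl in place of (1-amino-2-hydroxypropyl)carbonyl gives a 2.8-fold lower number from compound 3 to compound 4 (0.45 log units; beyond the scatter), and in place of (1-amino-2-hydroxyethyl)carbonyl it gives a 6.8-fold lower number from compound 1 to compound 4 (0.83 log units; beyond the scatter), whereas the earlier steps only altered the group on a retained carbonyl. In place of (1-amino-1-(hydroxymethyl)ethyl)carbonyl, the same group gives only a floor, an at least 13-fold lower number from compound 2 to compound 4 (1.13 log units; beyond the scatter). Compound 2 carries a limit and not a number: the limit of > 10000 nM in this assay, at which 1 of the 4 values shown sits.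

On these data alone, each of these exchanges removes the carbonyl and brings in the five-membered ring at once, so the two changes cannot be separated, and it stays open what an open-chain amino alcohol joined to the nitrogen through a methylene, or a pyrrolidine ring kept on a carbonyl, would give. As far as these compounds go, the chain on the core is the same throughout, so a longer chain, a shorter chain and the other stereoisomers of the (3-hydroxypyrrolidin-2-yl)methyl group also remain open.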